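The source may report more compounds than this note shows. Statements on the series, on what has been measured and on what is new or still open speak of the compounds shown alone.

Measured so far:
- Compound 1 `O=C1O[C@]2(CC[C@H](CNc3cnn(-c4ccccc4F)c3)CC2)CN1c1cncnc1` — 0.044
- Compound 2 `Cc1ccccc1-c1ccc(NC[C@H]2CC[C@]3(CC2)CN(c2cccnn2)C(=O)O3)nn1` — 0.051
- Compound 3 `O=C1O[C@]2(CC[C@H](CNc3ccn(-c4ccccc4F)n3)CC2)CN1c1ccccn1` — "not determined" (no result reported)

In an ADME assay on brain (Rattus norvegicus) for protein binding (a higher number here means a larger unbound share of the compound, a lower number a smaller unbound share), compound 1 gives 0.044, the lower of the two numbers recorded. Compound 2 gives 0.051, but the gap between them lies within the scatter of this assay, so the two cannot be told apart. Compound 3 has no value in this assay.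

Compound 4 `O=C1O[C@]2(CC[C@H](CNc3cnn(-c4ccccc4F)c3)CC2)CN1c1cccnc1F` has not yet been measured. It differs from compound 1 in a single place: 2-fluoropyridin-3-yl in place of pyrimidin-5-yl on an amide-type nitrogen in a ring. Among the measured compounds shown here, no pair of measured compounds shows a change of exactly this kind, so nothing in the data says how large a step to expect. Given that the only two numbers known sit so close together, the step from compound 1 to compound 4 is expected to be small, and most likely within the scatter, with no clear direction: a 1.2-fold lower number from compound 1 to compound 4 (0.06 log units; within the scatter). The unbound fraction of compound 4 is therefore estimated at 0.038, with a range from 0.019 to 0.075.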

Compound 4, unbound fraction: 0.019
Beside the measured number, compound 4's estimate is 2.0-fold (0.30 log units) above it; measured number inside the range.
By their numbers in this assay, from the lowest: compound 4; then compounds 1 and 2 (each within the scatter of the next).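

Replacing pyrimidin-5-yl with 2-fluoropyridin-3-yl on the amide-type nitrogen in the ring gives, in this assay, a 2.3-fold lower number from compound 1 to compound 4 (0.36 log units; beyond the scatter). Among the compounds shown here, this is the first step in the set that can be read for one place alone, and it shows that the group at this position can move the unbound share in brain tissue beyond the scatter while the rest of compound 1 stays fixed. No measurement here accounts for the drop.

The swap removes one ring nitrogen and adds a fluorine at once, so the compounds shown leave open which of these changes carries the step. Going by these compounds, a plain pyridin-3-yl or a 2-chloropyridin-3-yl at the same position would help separate the two, and it also remains open whether the step would hold with other groups elsewhere on the core.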